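The compounds below may be only part of what the source reports. "The series", "measured", "known", "first", "only" and "open" are said of these compounds alone.

Of the compounds shown here, three that share a core have been measured in a functional assay on the whole organism for inhibition, with Rattus norvegicus as the target, read by paw edema, with stated times of 1 h and 3 h; a higher number here means that more compound is needed for the effect, a lower number that less compound is needed: compound 1 (`C/C(=N\OCC(N)=O)c1ccc(Cl)cc1`), compound 2 (`C/C(=N\OCCC(=O)O)c1ccc(Cl)cc1`) and compound 3 (`CCOC(=O)CO/N=C(\C)c1ccc(Cl)cc1`). Compound 3 gives 32 mg/kg, which lies within the scatter of compound 1 at 24 mg/kg. Compound 2 stands apart at 80 mg/kg, and the move back from it is a 2.5-fold lower number from compound 2 to compound 3 (0.40 log units; beyond the scatter).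

Compound 4 (`CNC(=O)CO/N=C(\C)c1ccc(Cl)cc1`) has not yet been measured. It differs from compound 3 in one place, with methylamino in place of ethoxy on a carbonyl carbon.

The step that bears most directly on this change is a 1.3-fold higher number from compound 1 to compound 3 (0.12 log units; within the scatter), with ethoxy in place of amino on a carbonyl carbon. That exchange at the same carbon did not move the number beyond the scatter. Among the measured compounds shown here, the larger steps, a 3.3-fold higher number from compound 1 to compound 2 (0.52 log units; beyond the scatter) and the one back to compound 3, involve compound 2, whose chain differs as well, so they say less about this change. For the measured compounds named here, no measured compound carries methylamino, and that gap widens the uncertainty.

The expected result is a 1.1-fold lower number from compound 3 to compound 4 (0.06 log units; within the scatter), so no shift beyond the scatter is anticipated in this assay. For compound 4 the estimated value is 28 mg/kg, with an expected range from 14 mg/kg to 56 mg/kg.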

Compound 4, dose for half-maximal effect: 70 mg/kg
Estimate against measurement, compound 4: 2.5-fold (0.40 log units) below; the measured number lies above the stated range.
By their numbers in this assay, from the lowest: compounds 1 and 3 (each within the scatter of the next); then compounds 4 and 2 (each within the scatter of the next).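

In this assay, among the compounds shown here, the carbonyl carbon proves sensitive to what is attached to it in a way the earlier compounds did not reveal: the exchange of ethoxy for amino had stayed within the scatter, yet methylamino in place of ethoxy gives a 2.2-fold higher number from compound 3 to compound 4 (0.34 log units; beyond the scatter). The nitrogen substituent itself counts, since methyl in place of hydrogen on the amide-type nitrogen gives a 2.9-fold higher number from compound 1 to compound 4 (0.46 log units; beyond the scatter), which places the two amides apart while compound 1 and compound 3 remain together; methylcarbamoyl and carboxymethyl, by contrast, cannot be told apart, with a 1.1-fold lower number from compound 2 to compound 4 (0.06 log units; within the scatter). Nothing available explains why this one methyl shifts the number.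

The compounds shown leave open whether ethylamino or dimethylamino on the same carbonyl carbon would raise the number further or return it towards that of compound 1. They also leave open how a carboxylic acid formed directly at this carbon, with hydroxy in place of ethoxy, would compare with the ester and the amides.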